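Ethyl for Methylpyrrolidinyl on a Second Core

The source may report more compounds than this note shows. Statements on the series, on what has been measured and on what is new or still open speak of the compounds shown alone.

Compound 1 `C[C@H](NC(=O)[C@@H]1CCCN1C)c1ccc(NC(=O)N2CC(c3cccnc3)C2)cc1` serves as the reference. In a functional assay on COR-L23 cells (Homo sapiens) for antiproliferative activity, read by CellTiter-Glo, with a stated time of 72 h (on this read-out lower numbers stand for stronger inhibition and higher numbers for weaker inhibition), compound 1 gives 38 nM. Compound 2 `CCC(=O)N[C@@H](C)c1ccc(NC(=O)N2CC(c3cccnc3)C2)cc1` differs from it by ethyl in place of 1-methylpyrrolidin-2-yl on a carbonyl carbon, and in this assay compound 2 gives 120 nM, a change recorded as a 3.2-fold higher number from compound 1 to compound 2 (0.50 log units; beyond the scatter). Compound 3 `C[C@H](NC(=O)[C@@H]1CCCN1C)c1ccc(NC(=O)N2CC(c3cncc(N)c3)C2)cc1` carries the other core, set apart from compound 1 by amino in place of hydrogen on an aromatic carbon; in this assay compound 3 gives 200 nM, and the record shows a 5.3-fold higher number from compound 1 to compound 3 (0.72 log units; beyond the scatter). Compound 3 has the highest number of the three, although its gap to compound 2 lies within the scatter. Compound 4 `CCC(=O)N[C@@H](C)c1ccc(NC(=O)N2CC(c3cncc(N)c3)C2)cc1` has not yet been measured. It differs from compound 3 by ethyl in place of 1-methylpyrrolidin-2-yl on a carbonyl carbon, the same change that separates compound 1 from compound 2, with identical surroundings at the carbonyl carbon. Resting on that single earlier step, a 3.2-fold higher number from compound 1 to compound 2 (0.50 log units; beyond the scatter), the step to compound 4 is expected to be a 3.2-fold higher number from compound 3 to compound 4 (0.51 log units; beyond the scatter). Within the data shown here, with only one prior pair to lean on, the expectation remains loose. Compound 4 is therefore estimated at 640 nM, with a likely range from 250 nM to 1600 nM.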

Compound 4, half-maximal inhibitory concentration: 1580 nM
The estimate for compound 4 lay 2.5-fold (0.39 log units) below the measured number; measured number inside the range.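

In this assay, ethyl in place of 1-methylpyrrolidin-2-yl on a carbonyl carbon again gives a higher number on the second core, with a 7.9-fold higher number from compound 3 to compound 4 (0.90 log units; beyond the scatter), and the size of this step agrees with the earlier one: the same change on two cores in this assay, a 3.2-fold higher number (0.50 log units; beyond the scatter) from compound 1 to compound 2 and a 7.9-fold higher number (0.90 log units; beyond the scatter) from compound 3 to compound 4, 2.5-fold (0.40 log units) apart, within the scatter of two such steps. Amino in place of hydrogen on an aromatic carbon behaves likewise when the ethyl group is present, with a 13-fold higher number from compound 2 to compound 4 (1.12 log units; beyond the scatter), and this step also agrees with its earlier counterpart: the same change on two cores in this assay, a 5.3-fold higher number (0.72 log units; beyond the scatter) from compound 1 to compound 3 and a 13-fold higher number (1.12 log units; beyond the scatter) from compound 2 to compound 4, 2.5-fold (0.40 log units) apart, within the scatter of two such steps. Both changes therefore carried over in direction between these cores, and the difference in their size cannot be told from scatter, but the two comparisons rest on the same four compounds and show nothing about a third core or about other groups.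

The compounds shown leave open whether a longer chain or a piperidine ring on the carbonyl carbon would follow the same trend. They also leave open whether a methyl group or a fluorine atom on that aromatic carbon would give a step like that of the amino group.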